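Adding a 4-cyanobenzyl group to compound 2

The source may report more compounds than this note shows. Statements on the series, on what has been measured and on what is new or still open speak of the compounds shown alone.

Compound 1: `CC(C)(C)NCc1cc(Cl)cc(Nc2nc3cc(F)c(F)cc3n2Cc2ccc(C(F)(F)F)cc2)c1O`, > 50000 nM
Compound 2: `CCN(CC)Cc1ccc(Nc2nc3ccccc3[nH]2)cc1O`, > 50000 nM
Compound 3: `CCN(CC)Cc1cc(Nc2nc3ccccc3[nH]2)ccc1O`, > 50000 nM

These three results come from an ADME assay on CHO cells (Cricetulus griseus) for inhibition, read by MTT assay; a higher number here means a weaker inhibitor, a lower number a stronger inhibitor. Each one is a limit of the assay and not a true number. Compound 2 stands with the other two compounds at the limit of > 50000 nM in this assay, at which 3 of the 3 values shown sit. Within the data shown here, its exact strength as an inhibitor is therefore unknown, and no measured step between two closely related compounds is available as a guide.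

Compound 4 `CCN(CC)Cc1ccc(Nc2nc3ccccc3n2Cc2ccc(C#N)cc2)cc1O` is built from compound 2 by one change: 4-cyanobenzyl in place of hydrogen on an aromatic nitrogen. The nearest comparison is compound 1, which also carries a substituted benzyl group on an aromatic nitrogen and gives > 50000 nM, again a limit. That result offers no sign that such a group brings strong inhibition, although compound 1 differs from compound 2 in other places too.

In this assay only a modest move towards stronger inhibition is expected, and a further limit would be no surprise. The estimated size of the change is an at least 1.4-fold lower number from compound 2 to compound 4 (0.15 log units; that floor lies within the scatter). For compound 4 the expected value is 35000 nM, with an estimated range of 10000 nM to 80000 nM.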

Compound 4, half-maximal inhibitory concentration: 39000 nM
For compound 4 the middle estimate is 1.1-fold (0.05 log units) below the measured one, and the stated range covers the measured number.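

In this assay compound 4 gives 39000 nM, the only true number among the compounds shown, so with 4-cyanobenzyl on the aromatic nitrogen, inhibition reaches a level that can be read, even if the number is still high. The change amounts to an at least 1.2-fold lower number from compound 2 to compound 4 (0.10 log units; that floor lies within the scatter); only a floor on its size is known, and that floor alone does not show a change beyond the usual scatter. Compound 2 has only a limit, so the real size of the step cannot be read and may be larger than its floor: the limit of > 50000 nM in this assay, at which 3 of the 4 values shown sit.

The compounds shown leave open whether the readable value goes with the benzyl ring itself or with its nitrile, a question that a plain benzyl group or a 4-carboxybenzyl group on the same nitrogen could help to answer. Also open, going by these compounds, is whether 4-cyanobenzyl in place of hydrogen on the same aromatic nitrogen of compound 3 would likewise give a readable value.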